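This account rests on a few compounds, and the source may have more. Where it says the series, first, only, none or still open, it means among the compounds named here.

Measured so far in a functional assay on cells (Tumor Cell line, Homo sapiens) for cytotoxicity; on this read-out higher numbers stand for weaker inhibition of growth and lower numbers for stronger inhibition of growth:
compound 1 `COc1ccc(-c2cc(O)c3cccnc3n2)cc1`: 38000 nM
compound 2 `COc1ccccc1-c1cc(O)c2ccc(C)nc2n1`: 79400 nM
compound 3 `COc1ccc(-c2cc(O)c3cc(C)cnc3n2)cc1`: 6170 nM

Compound 2 gives the highest number of the three in this assay, and compound 3 the lowest. The difference between the core of compound 2 and the core of compound 3 is not broken down here. Between compound 3 and compound 1 the change is hydrogen in place of methyl on an aromatic carbon, and it gave a 6.2-fold higher number from compound 3 to compound 1 (0.79 log units; beyond the scatter).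

Compound 4 `COc1ccccc1-c1cc(O)c2cccnc2n1` has not yet been measured. It differs from compound 2 by hydrogen in place of methyl on an aromatic carbon, the same kind of change as from compound 3 to compound 1, though here the place is next to the ring nitrogen rather than two atoms from it. For the measured compounds named here, a weakening step is expected because a 6.2-fold higher number from compound 3 to compound 1 (0.79 log units; beyond the scatter) is the only measured instance of this kind of change; the estimated step is a 2.5-fold higher number from compound 2 to compound 4 (0.40 log units; beyond the scatter). Compound 4 is expected to give about 200000 nM in this assay, within 70000 nM to 600000 nM.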

Compound 4, concentration for 50% growth inhibition: 40700 nM
Compound 4: middle estimate off by 4.9-fold (0.69 log units), on the high side; the whole stated range lies above it.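

Hydrogen in place of methyl next to the ring nitrogen gives a 2.0-fold lower number from compound 2 to compound 4 (0.29 log units; within the scatter) in this assay, so at this place the change has no effect that can be told from the scatter. The same kind of change does not carry over in size from one core to the other: the same change on two cores in this assay, a 6.2-fold higher number (0.79 log units; beyond the scatter) from compound 3 to compound 1 and a 2.0-fold lower number (0.29 log units; within the scatter) from compound 2 to compound 4, 12-fold (1.08 log units) apart, beyond the scatter of two such steps Which feature of the two cores separates these steps is not shown, and two pairs give no rule for a further core in this series.

Only methyl and hydrogen appear at these places on the shared ring system. On these data alone, whether an amine, a carboxylic acid or a longer chain there would shift the growth-inhibition number on either core remains open.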